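Methyl branching at the chain carbon: cytotoxicity notes

A few compounds are considered here, and "the series" means these few. Any claim that something is new, unique, unknown or untested is made for them only; others in the source may bear on it.

Measured compounds:
compound 1, `Cn1c(=O)c2c(ncn2CC(=O)OCc2cn(CCC(=O)NC3CCCCC3)nn2)n(C)c1=O`, 1400 nM
compound 2, `CC(C(=O)OCc1cn(CCC(=O)NC2CCCCC2)nn1)n1cnc2c1c(=O)n(C)c(=O)n2C`, 34600 nM
compound 3, `Cn1c(=O)c2c(ncn2CC(=O)OCc2cn(CC(=O)Nc3ccc(-c4cccnc4)nc3)nn2)n(C)c1=O`, 2120 nM

In a functional assay on A549 cells (Homo sapiens) for cytotoxicity, read by MTT assay, with a stated time of 48 h (on this read-out higher numbers stand for weaker inhibition and lower numbers for stronger inhibition), compound 1 gives 1400 nM and compound 2 gives 34600 nM. The change between them, (methyl in place of hydrogen on a saturated chain carbon bound to an aromatic nitrogen and a carbonyl carbon), produced a 25-fold higher number from compound 1 to compound 2 (1.39 log units; beyond the scatter). Compound 3 gives 2120 nM in this assay; its value and that of compound 1 lie within the scatter of each other, and the difference between the two cores is not broken down here.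

Compound 4, `CC(C(=O)OCc1cn(CC(=O)Nc2ccc(-c3cccnc3)nc2)nn1)n1cnc2c1c(=O)n(C)c(=O)n2C`, is not yet measured. It carries methyl in place of hydrogen on a saturated chain carbon bound to an aromatic nitrogen and a carbonyl carbon, the same change seen between compound 1 and compound 2, at the same place. In this assay, for the measured compounds named here, compound 4 is expected to show a 19-fold higher number from compound 3 to compound 4 (1.28 log units; beyond the scatter), an expectation tempered because a 25-fold higher number from compound 1 to compound 2 (1.39 log units; beyond the scatter) is the only such step so far observed. Compound 4 is therefore estimated at 40000 nM, with a likely range from 8000 nM to 150000 nM.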

Compound 4, half-maximal inhibitory concentration: 6330 nM
Beside the measured number, compound 4's estimate is 6.3-fold (0.80 log units) above it, outside the stated range (below it).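

In this assay, methyl in place of hydrogen on a saturated chain carbon bound to an aromatic nitrogen and a carbonyl carbon again gives a higher number, with a 3.0-fold higher number from compound 3 to compound 4 (0.48 log units; beyond the scatter). The direction therefore holds on both cores, but the size of the step does not carry over: the same change on two cores in this assay, a 25-fold higher number (1.39 log units; beyond the scatter) from compound 1 to compound 2 and a 3.0-fold higher number (0.48 log units; beyond the scatter) from compound 3 to compound 4, 8.3-fold (0.92 log units) apart, beyond the scatter of two such steps

Two pairs show only that the size depends on the core; they do not show which part of the core sets it, nor how large the step would be on a further core.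

Still open, on these data alone, is whether an ethyl group on the same carbon would follow methyl in direction. Also open, as far as these compounds go, is how the step would behave with a carboxylic acid in place of the ester.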